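The source may hold more compounds than are shown below. What is called first, only, known or untested is meant among the compounds shown, and "the series" means these compounds.

In a functional assay on PC-3 cells (Homo sapiens) for inhibition, read by MTT assay, with stated times of 18 h and 4 h (a higher number here means a weaker inhibitor, a lower number a stronger inhibitor), compound 1 `CCCCCCCCCCCCCCCCOP(=O)(O)OCCSC(=S)N1CCN(C)CC1` gives 95200 nM. Compound 2 `CCCCCCCCCCOP(=O)(O)OCCSC(=S)N1CCN(C)CC1` gives 80000 nM, and the step is a 1.2-fold lower number from compound 1 to compound 2 (0.08 log units; within the scatter), so the two cannot be told apart. Compound 3 `CCCCCCCCOP(=O)(O)OCCSC(=S)N1CCN(C)CC1` is reported only as a limit, > 100000 nM. The steps to compound 3 are an at least 1.0-fold higher number from compound 1 to compound 3 (0.02 log units; that floor lies within the scatter) and an at least 1.2-fold higher number from compound 2 to compound 3 (0.09 log units; that floor lies within the scatter), so compound 1 stands level with compound 2 and close to the limit of > 100000 nM in this assay, at which 1 of the 3 values shown sits.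

Compound 4 `CCCCCCCCCCCCCCCCOP(=O)(O)OCCSC(=S)N1CCCC1` keeps the chain of compound 1 but carries pyrrolidin-1-yl in place of 4-methylpiperazin-1-yl on a thiocarbonyl carbon. For the measured compounds named here, none of the measured steps touches this place: all three change only the chain, and none of them leaves the scatter. They therefore bear on the new change only indirectly, and no step beyond the scatter is expected in this assay. The expected change is a 1.4-fold lower number from compound 1 to compound 4 (0.13 log units; within the scatter). For compound 4 the estimate is 70000 nM, with an estimated range from 20000 nM to 100000 nM, and a reading reported only as a limit remains possible.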

Compound 4, half-maximal inhibitory concentration: 65700 nM
Compound 4: middle estimate off by 1.1-fold (0.03 log units), on the high side; the measured number falls inside the stated range.
By their numbers in this assay, from the lowest: compounds 4, 2 and 1 (each within the scatter of the next). At a limit, above all of these: compound 3.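

In this assay, for the compounds shown here, this is the first change at the thiocarbonyl carbon, where the earlier steps had altered only the chain; pyrrolidin-1-yl in place of 4-methylpiperazin-1-yl gives a 1.4-fold lower number from compound 1 to compound 4 (0.16 log units; within the scatter). The five-membered ring with one hetero atom and the six-membered ring with two therefore cannot be told apart on this chain, so the change at this position has no readable effect on the number. Nothing measured here accounts for the size of this step.

On these data alone, it remains open whether a morpholin-4-yl ring, a piperidin-1-yl ring or an open-chain dimethylamino group at this carbon would move the number beyond the scatter. As far as these compounds go, it is also open how pyrrolidin-1-yl would read on the shorter chains of compound 2 and compound 3.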